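Lengthening the side chain of compound 3

The compounds below may be only part of what the source reports. "The series", "measured", "known", "first", "only" and "open" are said of these compounds alone.

In a physicochemical assay for solubility, in phosphate buffer, at pH 7.4 (a lower number here means a less soluble compound, a higher number a more soluble compound), compound 1 (`CC(C)n1nc(-c2ccnc3[nH]c(C4CCN(CC(=O)N(C)C)CC4)cc23)ccc1=O`) gives 11000 nM and compound 2 (`CC(C)n1cc(-c2ccnc3[nH]c(C4CCN(CC(=O)N(C)C)CC4)cc23)cnc1=O`) gives 910000 nM on the same scale. Compound 3 (`CC(C)Cn1cc(-c2ccnc3[nH]c(C4CCN(CC(=O)N(C)C)CC4)cc23)ccc1=O`) gives 390000 nM as the second highest of the three numbers, under compound 2 and over compound 1.

Compound 4 (`CN(C)C(=O)CN1CCC(c2cc3c(-c4ccc(=O)n(CCC5CCOCC5)c4)ccnc3[nH]2)CC1`) has not been measured yet. Its difference from compound 3 is (oxan-4-yl)methyl in place of isopropyl on a saturated chain carbon bound to an aromatic nitrogen with (oxan-4-yl)methyl in place of isopropyl on a saturated chain carbon bound to an aromatic nitrogen.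

For the measured compounds named here, the one measured single change gives an 83-fold higher number from compound 1 to compound 2 (1.92 log units; beyond the scatter) and is large, but it alters the aromatic ring, not this chain. Going by the values given here, it shows that one change can move the number far, yet no measured step tests this chain directly. In this assay the expected step is therefore a modest one, estimated as a 1.6-fold lower number from compound 3 to compound 4 (0.19 log units; within the scatter) with only a weak lean in its direction. The estimate for compound 4 is 250000 nM within an expected range of 50000 nM to 800000 nM for this measurement.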

Compound 4, solubility: 370000 nM
Estimate against measurement, compound 4: 1.5-fold (0.17 log units) below; the range from low to high includes it.
By their numbers in this assay, from the lowest: compound 1; then compounds 4 and 3 (each within the scatter of the next); then compound 2.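

Putting (oxan-4-yl)methyl in place of isopropyl on a saturated chain carbon bound to an aromatic nitrogen gives a 1.1-fold lower number from compound 3 to compound 4 (0.02 log units; within the scatter) in this assay. For the compounds shown here, this is the first direct test of this chain, and it shows that the position accepts (oxan-4-yl)methyl, with its six-membered non-aromatic ring and hydrogen-bond acceptor, in place of isopropyl, which has no ring, with no difference beyond the scatter of the read-out. Nothing measured here explains why the number holds across this change.

This single step does not show whether a group of another kind in this place, such as an amine or a carboxylic acid, would also stay within the scatter of compound 3. It also leaves open whether the same change would give a similar step on the aromatic rings of compound 1 or compound 2.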